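A few compounds are considered here, and "the series" means these few. Any claim that something is new, unique, unknown or untested is made for them only; others in the source may bear on it.

Measured so far in a functional assay on HCT-116 cells (Homo sapiens) for antiproliferative activity, read by MTT assay, with a stated time of 24 h; on this read-out higher numbers stand for weaker inhibition and lower numbers for stronger inhibition:

Compound 1, `COc1cccc(C(=O)Oc2ccc3c(=O)c(-c4cc(OC)c(OC)cc4OC)coc3c2)c1`, gives only a limit of the assay, > 10000 nM.
Compound 2, `COc1cc(OC)c(-c2coc3cc(OCc4ccccc4F)ccc3c2=O)cc1OC`, gives 2900 nM.
Compound 3, `COc1cc(OC)c(-c2coc3cc(OCc4ccccc4C)ccc3c2=O)cc1OC`, gives 2900 nM.

Compound 3 stands level with compound 2: no change at the digits printed from compound 2 to compound 3 (within the scatter). Against compound 1 there is an at least 3.4-fold lower number from compound 1 to compound 3 (0.53 log units; beyond the scatter), and for compound 2 likewise an at least 3.4-fold lower number from compound 1 to compound 2 (0.53 log units; beyond the scatter); both of these rest on (the limit of > 10000 nM in this assay, at which 1 of the 3 values shown sits), so their true size is not known, only that they are at least modest.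

Compound 4, `COc1cc(OC)c(-c2coc3cc(OCc4cccc(Br)c4)ccc3c2=O)cc1OC`, has not yet been measured. It differs from compound 3 in one place: 3-bromophenyl in place of 2-methylphenyl on a saturated chain carbon bound to an oxygen on an aromatic ring. Among the measured compounds shown here, of the measured steps, only the one from compound 2 to compound 3 touches the same benzyl ring, and there the swap of methyl for fluro, no change at the digits printed from compound 2 to compound 3 (within the scatter), stayed within the scatter. For the measured compounds named here, no measured pair moves a substituent to another carbon of that ring, so nothing here tells whether 3-bromobenzyl behaves differently from 2-methylbenzyl. Going by the values given here, with one within-scatter step as the only guide, the expectation is no change beyond the scatter: a 1.0-fold higher number from compound 3 to compound 4 (0.01 log units; within the scatter). Compound 4 is therefore estimated at 3000 nM, with a range from 1200 nM to 7500 nM.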

Compound 4, half-maximal inhibitory concentration: 1200 nM
Estimate against measurement, compound 4: 2.5-fold (0.40 log units) above; the range from low to high includes it.
By their numbers in this assay, from the lowest: compound 4; then compounds 2 and 3 (each within the scatter of the next). At a limit, above all of these: compound 1.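

In this assay, among the compounds shown here, this is the first change on the benzyl ring to move the number beyond the scatter, with a 2.4-fold lower number from compound 3 to compound 4 (0.38 log units; beyond the scatter) and the same size of step in a 2.4-fold lower number from compound 2 to compound 4 (0.38 log units; beyond the scatter). The ring on the saturated chain carbon bound to an oxygen on an aromatic ring is therefore not indifferent to what it carries: 2-fluorophenyl and 2-methylphenyl stand level, while 3-bromophenyl stands apart, though only modestly. The step from the (3-methoxyphenyl)carbonyl group also grows, to an at least 8.3-fold lower number from compound 1 to compound 4 (0.92 log units; beyond the scatter), and that size is only a floor:  the limit of > 10000 nM in this assay, at which 1 of the 4 values shown sits.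

The compounds shown do not separate the effect of the bromine itself from that of the ring carbon it sits on, since this change replaces the group and moves it at once. Also open, going by these compounds, is how this ring would respond to a different kind of group, such as an amine or a carboxylic acid, and how the activity would change if a longer chain replaced the single saturated carbon that links the ring to the oxygen.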